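This account rests on a few compounds, and the source may have more. Where it says the series, first, only, none or still open, it means among the compounds named here.

Before a compound can be judged useful, it helps to know how much of it cells can tolerate, and that is what an ADME assay on MT4 cells (Homo sapiens) for cytotoxicity, read by MTT assay (a lower number here means that less compound is tolerated, a higher number that more compound is tolerated), reports. Compound 1 `CCCCCOc1ccc(C(=O)N(C(=S)OCCN2C(=O)c3ccccc3C2=O)c2ccc(F)cc2)cc1` gives > 100000 nM in this assay, which is a limit of the assay and not a number. Going by the values given here, compound 2 `Cc1ccccc1C(=O)N(C(=S)OCCN1C(=O)c2ccccc2C1=O)c1ccc(Cl)cc1` gives 21000 nM, the only true number available so far, so it is the sole firm reference point for what follows.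

Compound 3 `O=C1c2ccccc2C(=O)N1CCOC(=S)N(C(=O)c1ccccc1[N+](=O)[O-])c1ccc(Cl)cc1` differs from compound 2 in one place: it has nitro in place of methyl on an aromatic carbon, ortho to a large group (nitro in place of methyl on an aromatic carbon). In other words, 2-methylphenyl becomes 2-nitrophenyl, while the rest of the molecule stays the same. Among the compounds with values here, no measured pair shows what this swap does in this assay, so no direction can be favoured, and the expectation is for no step beyond the usual scatter. The best starting point is therefore compound 2 at 21000 nM, with a wide margin on either side. The estimated step is a 1.1-fold lower number from compound 2 to compound 3 (0.02 log units; within the scatter). For compound 3 the expected value is 20000 nM, with an estimated range from 6000 nM to 80000 nM.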

Compound 3, half-maximal cytotoxic concentration: 21000 nM
For compound 3 the middle estimate is 1.1-fold (0.02 log units) below the measured one, and the stated range covers the measured number.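

In this assay, putting nitro in place of methyl on an aromatic carbon, ortho to a large group, gives no change at the digits printed from compound 2 to compound 3 (within the scatter). Going by these compounds alone, this is the first pair that differs in only one place, and it shows that at this position 2-nitrophenyl and 2-methylphenyl cannot be told apart in this read-out, even though nitro is the larger group and carries hydrogen-bond acceptors that methyl lacks. Compound 1 alone gives a limit of the assay rather than a number, whereas compound 2 and compound 3 both give true numbers, so the step between them can be read directly: the limit of > 100000 nM in this assay, at which 1 of the 3 values shown sits.

This is still a single swap on a single background, so it cannot show whether the position would respond in the same way to an amine, a carboxylic acid or a longer chain such as pentyloxy, the group found on compound 1. It also leaves open whether nitro in place of methyl would give the same result with other groups elsewhere on the shared core.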